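The source may report more compounds than this note shows. Statements on the series, on what has been measured and on what is new or still open speak of the compounds shown alone.

Compound 1 `O=C(Nc1ccccc1C(F)(F)F)C1CCc2ccccc2N1C(=O)c1ccccc1` gives 8120 nM in a functional assay on NUGC-3 cells (Homo sapiens) for cytotoxicity, read by sulforhodamine B assay, with a stated time of 72 h (a higher number here means a weaker inhibitor of growth, a lower number a stronger inhibitor of growth), the highest of the three measured numbers. Compound 3 `O=C(Nc1ccccc1O)C1CCc2ccccc2N1C(=O)c1ccccc1` gives 3780 nM. Compound 2 `O=C(Nc1cc(C(F)(F)F)cc(C(F)(F)F)c1)C1CCc2ccccc2N1C(=O)c1ccc(Cl)cc1` differs from compound 1 in two places at once; compound 2 gives 1660 nM. Within the data shown here, the only single change measured is a 2.1-fold lower number from compound 1 to compound 3 (0.33 log units; beyond the scatter), a change on an aromatic carbon. Compound 4 `CCC(=O)N1c2ccccc2CCC1C(=O)Nc1ccccc1C(F)(F)F` differs from compound 1 in one place: ethyl in place of phenyl on a carbonyl carbon. No measured step alters the group on this carbonyl carbon, so nothing among these three compounds tells which way the number should move. For compound 4 the step is therefore expected to stay within the usual scatter, as a 1.1-fold higher number from compound 1 to compound 4 (0.04 log units; within the scatter). Compound 4 is estimated at 9000 nM, within 2500 nM and 35000 nM.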

Compound 4, concentration for 50% growth inhibition: > 80000 nM
Compound 4: no number, only a limit; the forecaster's own chance of this, stated with the estimate: 15%; middle value at least 8.8-fold (0.94 log units) away from the limit.
By their numbers in this assay, from the lowest: compound 2; then compound 3; then compound 1. At a limit, above all of these: compound 4.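

Replacing benzoyl with propanoyl gives an at least 9.8-fold higher number from compound 1 to compound 4 (0.99 log units; beyond the scatter) in this assay and shows that the group on this carbonyl carbon strongly affects the result. Compound 4 gives > 80000 nM in this assay, which is a limit and not a number. Among these compounds, then, growth inhibition with a readable number goes with an aromatic ring at this place, though only this one swap tests it.

Going by these compounds, whether a longer chain such as hexyl, or a benzyl group, would restore a readable number stays open. So does whether the same swap would act alike on compound 3.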